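Fluoro placement on the pendant phenyl and cytotoxicity

The compounds below may be only part of what the source reports. "The series", "measured", "known", "first", "only" and "open" are said of these compounds alone.

Measured compounds:
compound 1, `COc1cc2c(Oc3ccc(NC(=O)c4cc(-c5ccccc5)ccn4)cc3F)ccnc2cc1OCCCN1CCN(C)CC1` — 82 nM
compound 2, `COc1cc2c(Oc3ccc(NC(=O)c4cc(-c5ccc(F)cc5)ccn4)cc3F)ccnc2cc1OCCCN1CCN(C)CC1` — 1460 nM
compound 3, `COc1cc2c(Oc3ccc(NC(=O)c4nccc(-c5ccc(F)cc5)n4)cc3F)ccnc2cc1OCCCN1CCN(C)CC1` — 42 nM

In a functional assay on HT-29 cells (Homo sapiens) for cytotoxicity, read by MTT assay, with a stated time of 72 h (on this read-out higher numbers stand for weaker inhibition and lower numbers for stronger inhibition), compound 1 gives 82 nM, while compound 2 gives 1460 nM. The two differ by a single change, (fluoro in place of hydrogen on an aromatic carbon), and that change brought an 18-fold higher number from compound 1 to compound 2 (1.25 log units; beyond the scatter). Compound 3 gives 42 nM, which lies within the usual scatter of the value of compound 1; how the core of compound 3 differs from that of compound 1 is not broken down here.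

Compound 4, `COc1cc2c(Oc3ccc(NC(=O)c4nccc(-c5ccc(F)cc5F)n4)cc3F)ccnc2cc1OCCCN1CCN(C)CC1`, has not been measured in this assay. It differs from compound 3 by fluoro in place of hydrogen on an aromatic carbon. This is the same kind of change as that from compound 1 to compound 2, but not the same: in compound 2 the entering fluoro sits para to a large group, whereas in compound 4 it enters ortho to a large group and meta to a fluoro group, and it enters on a different core.

Within the data shown here, because the only measured example of this kind of change gave an 18-fold higher number from compound 1 to compound 2 (1.25 log units; beyond the scatter), the account expects a step in the same direction from compound 3 to compound 4, though smaller, since the surroundings of the new fluoro and the core are not those of compound 2; the expected step is a 3.6-fold higher number from compound 3 to compound 4 (0.55 log units; beyond the scatter). Compound 4 is therefore estimated at 150 nM, with a likely range from 40 nM to 900 nM.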

Compound 4, half-maximal inhibitory concentration: 480 nM
Estimate against measurement, compound 4: 3.2-fold (0.51 log units) below, within the range that was stated.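

In this assay the second fluoro brought an 11-fold higher number from compound 3 to compound 4 (1.06 log units; beyond the scatter), a large step in the same direction as the earlier one, and the two steps do not differ by more than the scatter allows: the same change on two cores in this assay, an 18-fold higher number (1.25 log units; beyond the scatter) from compound 1 to compound 2 and an 11-fold higher number (1.06 log units; beyond the scatter) from compound 3 to compound 4, 1.6-fold (0.19 log units) apart, within the scatter of two such steps On these two pairs, then, putting a fluoro in place of a hydrogen on the aromatic carbon ring kept both its direction and its rough size when carried from the core of compound 1 to the core of compound 3. This does not show that the step is independent of the core or of the place, since the pairs differ in both at once: in the second pair the fluoro enters ortho to a large group and meta to a fluoro group, and two pairs are too few to show a rule for the series or to give a reason for the loss.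

The compounds shown leave open how the 2,4-difluorophenyl group would read on the core of compound 1, a comparison that would separate place from core. They also leave open how a chloro or a methoxy group entering at the same place would compare with the fluoro.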